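This account rests on a few compounds, and the source may have more. Where it says the series, first, only, none or still open, it means among the compounds named here.

Of the compounds shown here, three have been measured in a physicochemical assay for solubility, in phosphate buffer, measured as kinetic solubility, at pH 7.4, tested at 250 uM (a lower number here means a less soluble compound, a higher number a more soluble compound), and their numbers all lie within the scatter of one another. Compound 1 (`CN(C)S(=O)(=O)c1cc(C(=O)O)ccc1NCCCC(F)(F)F`) gives 245000 nM, compound 2 (`CN(C)S(=O)(=O)c1cc(C(=O)O)ccc1NCCCCCC(F)(F)F`) gives 249000 nM, and compound 3 (`COCCCCNc1ccc(C(=O)O)cc1S(=O)(=O)N(C)C`) gives 247000 nM. Compound 3 therefore stands within the scatter of both others, and no order can be read among the three.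

The next step leads to compound 4 (`COCCCCCCNc1ccc(C(=O)O)cc1S(=O)(=O)N(C)C`), with this difference: 2-methoxyethyl in place of methoxy on a saturated chain carbon, four bonds along the chain from a nitrogen on an aromatic ring. The nearest measured precedent is a 1.0-fold higher number from compound 1 to compound 2 (0.01 log units; within the scatter), where 3,3,3-trifluoropropyl takes the place of trifluoromethyl, also a larger group entering on the chain. That step lies within the scatter. The two other steps, a 1.0-fold higher number from compound 1 to compound 3 (0.00 log units; within the scatter) and a 1.0-fold lower number from compound 2 to compound 3 (0.00 log units; within the scatter), exchange a fluorinated group for a methoxy-bearing one and also lie within the scatter. Among the measured compounds shown here, no measured step in this set leaves the scatter, so no step beyond it is expected in this assay, in either direction. The expected step is a 1.0-fold lower number from compound 3 to compound 4 (0.00 log units; within the scatter). Compound 4 is estimated at 245000 nM, with an expected range of 170000 nM to 260000 nM.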

Compound 4, solubility: > 250000 nM
Compound 4 ended at the assay's limit (the forecaster's own chance of this, stated with the estimate: 15%); at least 1.0-fold (0.00 log units) between middle value and limit.
By their numbers in this assay, from the lowest: compounds 1, 3 and 2 (each within the scatter of the next). At a limit, above all of these: compound 4.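

In this assay compound 4 gives > 250000 nM, which is a limit of the assay and not a number: the limit of > 250000 nM in this assay, at which 1 of the 4 values shown sits.

The readable steps are an at least 1.0-fold higher number from compound 3 to compound 4 (0.00 log units; that floor lies within the scatter) and an at least 1.0-fold higher number from compound 1 to compound 4 (0.00 log units; that floor lies within the scatter), while a number no lower from compound 2 to compound 4 (the limit leaves the size open) cannot be read. New at this place, on a saturated chain carbon, four bonds along the chain from a nitrogen on an aromatic ring, is that 2-methoxyethyl in place of methoxy brings no lower number, though the size of any rise stays unknown.

With three values within the scatter of one another and the fourth at the limit, this assay gives no order among these chains and no sign of how far the chain can be changed before the number falls. Open, going by these compounds, is whether an amine, a carboxylic acid or a phenyl ring at the chain end, or a still longer chain of carbons with no oxygen or fluorine, would give a number clearly lower than those of the four compounds.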